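Clearing the sulfonamide nitrogen of compound 3

The source may hold more compounds than are shown below. What is called first, only, known or untested is meant among the compounds shown, and "the series" means these compounds.

Compound 1 `Cc1cc(C)nc(NS(=O)(=O)c2ccc(Nc3nncc4ccccc34)cc2)n1`: 3.4 nM
Compound 2 `Fc1ccc(Nc2nncc3ccccc23)cc1`: 5.4 nM
Compound 3 `Cc1cc(NS(=O)(=O)c2ccc(Nc3nncc4ccccc34)cc2)no1`: 54 nM

All three numbers come from a functional assay on OVCAR-3 cells (Homo sapiens) for antiproliferative activity, read by sulforhodamine B assay, with a stated time of 72 h; on this read-out higher numbers stand for weaker inhibition and lower numbers for stronger inhibition. Compound 3 has the highest number of the three, at 54 nM, which makes it the weakest inhibitor of this small set.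

The next compound, compound 4 `NS(=O)(=O)c1ccc(Nc2nncc3ccccc23)cc1`, differs from compound 3 in one place: hydrogen in place of 5-methyl-1,2-oxazol-3-yl on a sulfonamide nitrogen. Put simply, this is hydrogen in place of 5-methyl-1,2-oxazol-3-yl on a sulfonamide nitrogen.

Within the data shown here, only one measured step touches this nitrogen. It is a 16-fold higher number from compound 1 to compound 3 (1.20 log units; beyond the scatter), a large step in which 5-methyl-1,2-oxazol-3-yl took the place of 4,6-dimethylpyrimidin-2-yl. This shows that the group on the nitrogen can shift the number strongly. However, that step swaps one ring for another, and no measured compound has a bare hydrogen there, so it indicates possible size better than direction. Compound 2, which has no sulfonamide at all, reaches 5.4 nM, so a low number does not require such a ring. A moderate move toward a lower number is therefore expected, though with wide uncertainty. The expected step in this assay is a 2.7-fold lower number from compound 3 to compound 4 (0.43 log units; beyond the scatter). Compound 4 is estimated at 20 nM, with an expected range from 4 nM to 100 nM.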

Compound 4, half-maximal inhibitory concentration: 14 nM
For compound 4 the middle estimate is 1.4-fold (0.15 log units) above the measured one; measured number inside the range.
By their numbers in this assay, from the lowest: compounds 1 and 2 (each within the scatter of the next); then compound 4; then compound 3.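

In this assay, the step of a 3.9-fold lower number from compound 3 to compound 4 (0.59 log units; beyond the scatter) shows that this nitrogen needs no ring to keep a low number, and that with a bare hydrogen the number falls compared with 5-methyl-1,2-oxazol-3-yl. The step of a 4.1-fold higher number from compound 1 to compound 4 (0.61 log units; beyond the scatter) points the other way for the second ring: taking away 4,6-dimethylpyrimidin-2-yl raises the number, so the bare nitrogen sits between the two ring-bearing compounds, and a ring here can move the number in either direction, depending on which ring it is. The step of a 2.6-fold higher number from compound 2 to compound 4 (0.41 log units; beyond the scatter) adds a comparison at the level of the whole group, with sulfamoyl in place of fluoro on an aromatic carbon, and the fluoro compound keeps the lower number.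

Nothing among the data says why the two rings differ in this way. The compounds shown leave open where a single methyl group, an acetyl group or a plain phenyl ring on this nitrogen would fall relative to the bare hydrogen and to the two rings already compared.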